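The source may report more compounds than this note shows. Statements on the series, on what has been measured and on what is new or still open speak of the compounds shown alone.

Working notes on the series in a functional assay on Bel-7402 cells (Homo sapiens) for cytotoxicity, read by MTT assay, with a stated time of 48 h; on this read-out higher numbers stand for weaker inhibition and lower numbers for stronger inhibition. Compound 1 `COc1ccc(-c2c[nH]c(=O)n2-c2cc(OC)c(OC)c(OC)c2)cc1N` gives > 50000 nM, which is a limit of the assay and not a number. Compound 2 `COc1ccc(-c2cn(C(=O)Nc3cc(OC)c(OC)c(OC)c3)c(=O)n2-c2cc(OC)c(OC)c(OC)c2)cc1N` gives 10100 nM. Compound 3 `COc1cc(-n2c(-c3ccc(Br)cc3)cn(C(C)=O)c2=O)cc(OC)c1OC` gives 1200 nM, the lower of the two actual numbers, and its gap to compound 2 lies beyond the scatter. Compounds 1, 2 and 3 are not related by any single change, so their values set a rough scale and give no measured effect for any one group.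

Next in line is compound 4 `COc1cc(-n2c(-c3ccc([N+](=O)[O-])cc3)cn(C(C)=O)c2=O)cc(OC)c1OC`, which keeps the frame of compound 3 and alters one substituent: nitro in place of bromo on an aromatic carbon. This is nitro in place of bromo on an aromatic carbon, para to a large group, or 4-bromophenyl to 4-nitrophenyl. Among the compounds with values here, no measured pair covers this exchange, so the expectation starts from compound 3 at 1200 nM and carries a wide margin. A shift within the scatter is the most likely outcome, with a slight lean toward a higher number. The expected step is a 1.7-fold higher number from compound 3 to compound 4 (0.22 log units; within the scatter). For compound 4 the estimated value is 2000 nM, with an expected range of 500 nM to 10000 nM.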

Compound 4, half-maximal inhibitory concentration: > 50000 nM
Compound 4: no number, only a limit; the forecaster's own chance of this, stated with the estimate: 5%; middle value at least 25-fold (1.39 log units) from the limit.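

In this assay, within the data shown here, nitro in place of bromo on an aromatic carbon, para to a large group, is the first single change with a readable effect: an at least 41-fold higher number from compound 3 to compound 4 (1.61 log units; beyond the scatter). The value therefore responds strongly to what sits on this carbon, which compounds 1, 2 and 3, unrelated to one another by any single change, could not show. Going by these compounds, compound 4 reaches only a limit of the assay and not a number, so the step gives a lower bound on the effect and its true size stays unknown: the limit of > 50000 nM in this assay, at which 2 of the 4 values shown sit.

On these data alone, with only bromo and nitro compared at this position, it remains open whether a chlorine, a nitrile, an amine or a carboxylic acid on the same carbon would stay close to compound 3 or fall away like compound 4. As far as these compounds go, it also remains open whether the same exchange would have a comparable effect on the frames of compound 1 or compound 2, since neither compound forms a pair that tests it.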